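The compounds below may be only part of what the source reports. "The series", "measured", "known", "first", "only" and "open" are said of these compounds alone.

Working notes on the series. The three measured compounds share one core and differ only in the group carried on an aromatic carbon of the terminal benzene ring. Compound 1 `CCC(C)(C)Cc1c[nH]c(CCc2ccc(-c3cccc(C)n3)cc2)n1` gives 19 nM in a functional assay on HEK293 cells for agonist activity at Bombesin receptor subtype-3 (Mus musculus), read by luminescence and calcium flux, with a stated time of 10 min; on this read-out higher numbers stand for an effect only at larger amounts of compound and lower numbers for an effect already at smaller amounts. Compound 2 `CCC(C)(C)Cc1c[nH]c(CCc2ccc(-n3ncnn3)cc2)n1` gives 25 nM in this assay, and the step of a 1.3-fold higher number from compound 1 to compound 2 (0.12 log units; within the scatter) is within the scatter. Compound 3 `CCC(C)(C)Cc1c[nH]c(CCc2ccc(-n3ccnn3)cc2)n1` gives 57 nM in this assay, the highest of the three numbers; the steps leading to it are a 2.3-fold higher number from compound 2 to compound 3 (0.36 log units; beyond the scatter) and a 3.0-fold higher number from compound 1 to compound 3 (0.48 log units; beyond the scatter), both beyond the scatter.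

Compound 4 `CCC(C)(C)Cc1c[nH]c(CCc2ccc(-c3ccc(F)cn3)cc2)n1` is not yet measured. The change from compound 3 is 5-fluoropyridin-2-yl in place of 1H-1,2,3-triazol-1-yl on an aromatic carbon. The step that bears on it most directly is a 3.0-fold higher number from compound 1 to compound 3 (0.48 log units; beyond the scatter), in which a methyl-bearing pyridin-2-yl gave way to the triazolyl group; compound 4 runs that exchange in the opposite direction with a fluorine-bearing pyridin-2-yl. The step of a 2.3-fold higher number from compound 2 to compound 3 (0.36 log units; beyond the scatter) likewise places the triazolyl group at the high end. A lower number in this assay is therefore expected for compound 4, of roughly the size of the reverse of those steps, a 2.9-fold lower number from compound 3 to compound 4 (0.45 log units; beyond the scatter). The estimate for compound 4 is 20 nM, with a range from 8 nM to 50 nM.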

Compound 4, half-maximal effective concentration: 16 nM
For compound 4 the middle estimate is 1.3-fold (0.10 log units) above the measured one; the measured number falls inside the stated range.
By their numbers in this assay, from the lowest: compounds 4, 1 and 2 (each within the scatter of the next); then compound 3.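

In this assay the exchange of 1H-1,2,3-triazol-1-yl for 5-fluoropyridin-2-yl gives a 3.6-fold lower number from compound 3 to compound 4 (0.55 log units; beyond the scatter), so a second pyridin-2-yl group, now bearing fluorine in place of methyl, also stands apart from the triazolyl compound. The two pyridin-2-yl groups cannot be told apart at this position, with a 1.2-fold lower number from compound 1 to compound 4 (0.07 log units; within the scatter), and the same holds for the tetrazolyl and fluoropyridinyl groups, with a 1.6-fold lower number from compound 2 to compound 4 (0.19 log units; within the scatter), so a five-membered and a six-membered aromatic ring can give numbers within the scatter of each other here. Among the four compounds only compound 3 stands apart, and nothing on hand accounts for this.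

Open, on these data alone, is whether the unsubstituted pyridin-2-yl group matches its methyl and fluoro counterparts. Also open, as far as these compounds go, is how an amine or a carboxylic acid would fare at this position.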